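Shortening the amide substituent from butyl to ethyl

The compounds below may be only part of what the source reports. "The series", "measured", "known", "first", "only" and "open" are said of these compounds alone.

Compound 1 `CC[C@@H]1C(=O)N(C)c2cnc(-n3ccc4cc(C(N)=O)ccc43)nc2N1C1CCCC1`: 4350 nM
Compound 2 `CC[C@@H]1C(=O)N(C)c2cnc(-n3ccc4cc(C(=O)NC(C)C)ccc43)nc2N1C1CCCC1`: 1780 nM
Compound 3 `CCCCNC(=O)c1ccc2c(ccn2-c2ncc3c(n2)N(C2CCCC2)[C@H](CC)C(=O)N3C)c1`: 1160 nM

In a functional assay on A549 cells (Homo sapiens) for antiproliferative activity, read by CCK-8 assay, with a stated time of 72 h (on this read-out higher numbers stand for weaker inhibition of growth and lower numbers for stronger inhibition of growth), compound 3 gives the lowest of the three numbers; compound 2 sits within the scatter of it, as a 1.5-fold lower number from compound 2 to compound 3 (0.19 log units; within the scatter) shows, while compound 1 lies beyond it, as a 3.8-fold lower number from compound 1 to compound 3 (0.57 log units; beyond the scatter) shows. Compound 4 `CCNC(=O)c1ccc2c(ccn2-c2ncc3c(n2)N(C2CCCC2)[C@H](CC)C(=O)N3C)c1` differs from compound 3 by hydrogen in place of ethyl on a saturated chain carbon, two bonds along the chain from an amide-type nitrogen. Among the measured compounds shown here, the steps that bear on this change are those on the amide nitrogen: a 2.4-fold lower number from compound 1 to compound 2 (0.39 log units; beyond the scatter), a 3.8-fold lower number from compound 1 to compound 3 (0.57 log units; beyond the scatter) and a 1.5-fold lower number from compound 2 to compound 3 (0.19 log units; within the scatter). Ethyl stands between the hydrogen of compound 3's nearest larger neighbour, compound 1, and the butyl of compound 3, so a modest rise in this assay is expected, smaller than the step from compound 1. The expected step is a 1.6-fold higher number from compound 3 to compound 4 (0.21 log units; within the scatter). Compound 4 is expected at 1900 nM, ranging from 900 nM to 4000 nM.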

Compound 4, concentration for 50% growth inhibition: 1120 nM
Beside the measured number, compound 4's estimate is 1.7-fold (0.23 log units) above it; measured number inside the range.
By their numbers in this assay, from the lowest: compounds 4, 3 and 2 (each within the scatter of the next); then compound 1.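

In this assay, taking butyl down to ethyl leaves the number unresolved (a 1.0-fold lower number from compound 3 to compound 4 (0.02 log units; within the scatter)), and the isopropyl amide cannot be told apart from the ethyl amide either (a 1.6-fold lower number from compound 2 to compound 4 (0.20 log units; within the scatter)). Ethyl on the amide nitrogen is thus already enough to separate from the unsubstituted amide (a 3.9-fold lower number from compound 1 to compound 4 (0.59 log units; beyond the scatter)), and among the three substituents shown, neither the extra chain length of butyl nor the branching of isopropyl gives a step beyond the scatter. From the compounds shown here alone, whether methyl on the amide nitrogen keeps this level, or whether a chain ending in an amine or a carboxylic acid does, remains open. Nothing shown accounts for this flat response to the substituent on the amide nitrogen.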